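This account rests on a few compounds, and the source may have more. Where it says the series, first, only, none or still open, it means among the compounds named here.

Measured compounds:
compound 1, `CCCC(=O)Nc1ccc(S(=O)(=O)N(CC(N)=O)c2ccc(N(CC(N)=O)S(=O)(=O)c3ccc(OC)cc3)c3ccccc23)cc1`: > 100000 nM
compound 2, `CCN1CCN(CC(=O)Nc2ccc(S(=O)(=O)N(CC(N)=O)c3ccc(N(CC(N)=O)S(=O)(=O)c4ccc(OC)cc4)c4ccccc34)cc2)CC1`: > 100000 nM

In a functional assay on cells (Peritoneal macrophage, Mus musculus) for cytotoxicity, with a stated time of 24 h (on this read-out higher numbers stand for lower toxicity in this test and lower numbers for higher toxicity in this test), compound 1 gives > 100000 nM, which is a limit of the assay rather than a number. Compound 2 gives > 100000 nM, likewise a limit. Going by the values given here, the single measured step, a step that the two limits leave unreadable from compound 1 to compound 2, is therefore not readable in size or direction, and the only evidence on the numbers is the limit of > 100000 nM in this assay, at which 2 of the 2 values shown sit.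

Compound 3, `COc1ccc(S(=O)(=O)N(CC(N)=O)c2ccc(N(CC(N)=O)S(=O)(=O)c3ccc(NC(=O)CN4CCN(C(C)C)CC4)cc3)c3ccccc23)cc1`, differs from compound 2 by methyl in place of hydrogen on a saturated chain carbon bound to an amine nitrogen in a ring and a saturated chain carbon. Among the compounds with values here, no measured step bears on this change in a readable way, since both values shown are limits. Within the data shown here, with compound 2 at the limit and no step to read, compound 3 is expected to behave no differently beyond the scatter, that is a step that the limit leaves unreadable from compound 2 to compound 3, most probably again reported only as a limit. The estimate for compound 3 in this assay is 150000 nM, within the range 60000 nM to 400000 nM.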

Compound 3, half-maximal cytotoxic concentration: > 100000 nM
Compound 3: a limit, no number; the forecaster's own chance of this, stated with the estimate: 85%; the middle value is on the limit's open side.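

In this assay, going by these compounds alone, compound 3 again gives a limit rather than a number, so no step among compound 1, compound 2 and compound 3 can be read: the limit of > 100000 nM in this assay, at which 3 of the 3 values shown sit. The compounds shown leave open whether any of these side-chain changes alters toxicity in this test.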